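A few compounds are considered here, and "the series" means these few. Any claim that something is new, unique, unknown or untested is made for them only; others in the source may bear on it.

Compound 1 `O=C(CCCCCCCNC(=O)c1cc(=O)c(O)co1)Nc1ccccc1` in a functional assay on HCT-116 cells (Homo sapiens) for inhibition, read by colorimetric assay, with a stated time of 3 days (on this read-out higher numbers stand for weaker inhibition and lower numbers for stronger inhibition), gives > 100000 nM, which is a limit of the assay rather than a number. Compound 2 `NC(=O)C(=O)NCCCCCCCC(=O)Nc1ccccc1` in this assay gives > 100000 nM, again a limit. Compound 3 `O=C(CCCCNC(=O)c1cc(=O)c(O)co1)Nc1ccccc1` in this assay gives > 100000 nM, also a limit.

Compound 2 arises from compound 1 by a group of 3 heavy atoms (1 carbon, 1 nitrogen, 1 oxygen; no ring) in place of a group of 8 heavy atoms (5 carbon, 3 oxygen; one six-membered aromatic ring with 1 hetero atom), on a carbonyl carbon. The step that the two limits leave unreadable from compound 1 to compound 2 cannot be sized, since both values sit at the limit of > 100000 nM in this assay, at which 3 of the 3 values shown sit. Compound 4 `NC(=O)C(=O)NCCCCC(=O)Nc1ccccc1`, not yet measured, arises from compound 3 by the same change, (a group of 3 heavy atoms (1 carbon, 1 nitrogen, 1 oxygen; no ring) in place of a group of 8 heavy atoms (5 carbon, 3 oxygen; one six-membered aromatic ring with 1 hetero atom), on a carbonyl carbon). The difference between the core of compound 1 and the core of compound 3 is not broken down here.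

With every measured compound sitting at the limit of > 100000 nM in this assay, at which 3 of the 3 values shown sit, a step that the limit leaves unreadable from compound 3 to compound 4 is expected, and compound 4 is expected to remain at the limit as well. Compound 4 is estimated at 200000 nM, with a likely range from 80000 nM to 1000000 nM.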

Compound 4, half-maximal inhibitory concentration: > 100000 nM
Compound 4 was reported as a limit (the forecaster's own chance of this, stated with the estimate: 90%); the middle value does not contradict the limit.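

Compound 3 and compound 4 both give a limit rather than a number in this assay, so the change between them cannot be sized: the limit of > 100000 nM in this assay, at which 4 of the 4 values shown sit.

The compounds shown leave open how the carbamoyl group compares with the group it replaces, since neither yields a measurable value.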